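Urea series: from 4-nitrophenyl to 3-chlorophenyl

A few compounds are considered here, and "the series" means these few. Any claim that something is new, unique, unknown or untested is made for them only; others in the source may bear on it.

Measured in a functional assay on MDA-MB-231 cells (Homo sapiens) for cytotoxicity, read by MTT assay, with a stated time of 48 h; on this read-out higher numbers stand for weaker inhibition and lower numbers for stronger inhibition:
compound 1 `Fc1ccc(C(CCCCOCc2ccc(Oc3ccc(Cl)cc3)cc2)c2ccc(F)cc2)cc1`: > 20000 nM (a limit)
compound 2 `O=C(OCCCC(c1ccc(F)cc1)c1ccc(F)cc1)c1cc(Cl)c(OCc2ccccc2)c(Cl)c1`: > 20000 nM (a limit)
compound 3 `O=C(NCCCCC(c1ccc(F)cc1)c1ccc(F)cc1)Nc1ccc([N+](=O)[O-])cc1`: 6470 nM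

Compound 3 stands alone with a real number, 6470 nM. Compound 1 and compound 2 report only a limit, (the limit of > 20000 nM in this assay, at which 2 of the 3 values shown sit).

Compound 4 `O=C(NCCCCC(c1ccc(F)cc1)c1ccc(F)cc1)Nc1cccc(Cl)c1` carries 3-chlorophenyl in place of 4-nitrophenyl on an amide-type nitrogen. Within the data shown here, no measured step covers this exchange, so the expectation rests on compound 3 at 6470 nM alone. In this assay the expected change is none beyond the scatter, an estimated 1.1-fold higher number from compound 3 to compound 4 (0.03 log units; within the scatter). For compound 4 the estimated value is 7000 nM, with an expected range of 2500 nM to 18000 nM.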

Compound 4, half-maximal inhibitory concentration: 5070 nM
Compound 4: middle estimate off by 1.4-fold (0.14 log units), on the high side; measured number inside the range.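

In this assay, the exchange of 4-nitrophenyl for 3-chlorophenyl on an amide-type nitrogen gives a 1.3-fold lower number from compound 3 to compound 4 (0.11 log units; within the scatter), so the two ureas cannot be told apart. The hydrogen-bond acceptors counted on 4-nitrophenyl leave with this exchange, and 3-chlorophenyl, which has none, gives a value within the scatter of compound 3. Compound 1 and compound 2 remain limits, not numbers: the limit of > 20000 nM in this assay, at which 2 of the 4 values shown sit.

Still open, as far as these compounds go, is whether an amine or a carboxylic acid on this phenyl ring would move the value beyond the scatter. A longer chain in the shared core is equally untested here.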